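Ether to ester at the aromatic oxygen of the shared core

The compounds below may be only part of what the source reports. "The series", "measured", "known", "first", "only" and "open" are said of these compounds alone.

Measured compounds in a functional assay on DLD-1 cells (Homo sapiens) for cytotoxicity, with a stated time of 48 h; a lower number here means a stronger inhibitor, a higher number a weaker inhibitor:
compound 1 `C[S+]([O-])/C=C/c1cc(=O)c2ccccc2o1`, 8000 nM
compound 2 `CC(C)COc1ccc2oc(/C=C/[S+](C)[O-])cc(=O)c2c1`, 5000 nM
compound 3 `CCCCOc1ccc2oc(/C=C/[S+](C)[O-])cc(=O)c2c1`, 4800 nM

Compound 3 gives the lowest of the three numbers, but its gaps to compound 2 and to compound 1 are within the scatter, so no order among the three is established. Compound 4 `CCCCC(=O)Oc1ccc2oc(/C=C/[S+](C)[O-])cc(=O)c2c1` differs from compound 3 by butylcarbonyl in place of butyl on an oxygen on an aromatic ring. The steps of a 1.6-fold lower number from compound 1 to compound 2 (0.20 log units; within the scatter) and a 1.7-fold lower number from compound 1 to compound 3 (0.22 log units; within the scatter) show that adding an alkoxy group to the shared core changes little, and a 1.0-fold lower number from compound 2 to compound 3 (0.02 log units; within the scatter) shows that the shape of the chain on that oxygen changes little either. Among the measured compounds shown here, no measured step introduces a carbonyl at this position, so the expectation rests on the flatness of the series: for compound 4 a step of a 1.0-fold higher number from compound 3 to compound 4 (0.02 log units; within the scatter) is expected, within the scatter, with an estimated value of 5000 nM and a range of 2500 nM to 10000 nM.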

Compound 4, half-maximal inhibitory concentration: 6700 nM
Estimate against measurement, compound 4: 1.3-fold (0.13 log units) below; the range from low to high includes it.
By their numbers in this assay, from the lowest: compounds 3, 2, 4 and 1 (each within the scatter of the next).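

In this assay, the carbonyl brought onto this oxygen gives a 1.4-fold higher number from compound 3 to compound 4 (0.14 log units; within the scatter) and, against the branched ether, a 1.3-fold higher number from compound 2 to compound 4 (0.13 log units; within the scatter). Set against the hydrogen of the core, (butylcarbonyl)oxy gives a 1.2-fold lower number from compound 1 to compound 4 (0.08 log units; within the scatter), so at this position the change from ether to ester, like the alkoxy groups before it, produces no readable difference. No measured information bears on the reason for this flatness. As far as these compounds go, whether an amine, a carboxylic acid or a longer chain on this oxygen would move the number beyond the scatter remains open.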